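Swapping Methyl for Bromo: Expectation for Compound 4

The source may report more compounds than this note shows. Statements on the series, on what has been measured and on what is new or still open speak of the compounds shown alone.

Compound 1 `Cc1ccc(-c2csc(NC(=O)COc3ccccc3C)n2)cc1` gives 53500 nM in a functional assay on MCF7 cells (Homo sapiens) for cytotoxicity, read by MTT assay, with a stated time of 48 h; on this read-out lower numbers stand for stronger inhibition and higher numbers for weaker inhibition. Compound 2 `Cc1ccccc1OCC(=O)Nc1nc(-c2ccc(Br)cc2)cs1` differs from it by bromo in place of methyl on an aromatic carbon, and this change makes a 1.3-fold lower number from compound 1 to compound 2 (0.13 log units; within the scatter). Compound 3 `Cc1ccc(OCC(=O)Nc2nc(-c3ccc(C)cc3)cs2)cc1` has a core that differs from that of compound 1 by 4-methylphenyl in place of 2-methylphenyl on an oxygen on a saturated carbon; in this assay compound 3 gives 41300 nM, while compound 2 gives 40100 nM; the step of a 1.3-fold lower number from compound 1 to compound 3 (0.11 log units; within the scatter). Compound 4 `Cc1ccc(OCC(=O)Nc2nc(-c3ccc(Br)cc3)cs2)cc1` has not yet been measured; it differs from compound 3 by bromo in place of methyl on an aromatic carbon, the same change, at the same kind of place, as from compound 1 to compound 2. The step of a 1.3-fold lower number from compound 3 to compound 4 (0.10 log units; within the scatter) is expected to be small because the earlier step of a 1.3-fold lower number from compound 1 to compound 2 (0.13 log units; within the scatter) stayed within the scatter, though this rests on a single prior example. For compound 4 a value of 33000 nM is estimated, lying between 16000 nM and 70000 nM.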

Compound 4, half-maximal inhibitory concentration: 52200 nM
Beside the measured number, compound 4's estimate is 1.6-fold (0.20 log units) below it; low and high end bracket the measured number.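

In this assay, bromo in place of methyl on the aromatic carbon gives a 1.3-fold higher number from compound 3 to compound 4 (0.10 log units; within the scatter), and the two steps for this change agree: the same change on two cores in this assay, a 1.3-fold lower number (0.13 log units; within the scatter) from compound 1 to compound 2 and a 1.3-fold higher number (0.10 log units; within the scatter) from compound 3 to compound 4, 1.7-fold (0.23 log units) apart, within the scatter of two such steps. Putting 4-methylphenyl in place of 2-methylphenyl gives a 1.3-fold higher number from compound 2 to compound 4 (0.11 log units; within the scatter), and its two steps agree as well: the same change on two cores in this assay, a 1.3-fold lower number (0.11 log units; within the scatter) from compound 1 to compound 3 and a 1.3-fold higher number (0.11 log units; within the scatter) from compound 2 to compound 4, 1.7-fold (0.23 log units) apart, within the scatter of two such steps. On these two cores, then, each change stays within the scatter, but this does not show that a change with a real effect would carry from one core to another, and the opposite directions of the steps cannot be read as a trend.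

The compounds shown leave open whether an amine or a carboxylic acid in place of the bromo would take the number beyond the scatter. They also leave open what a longer chain in place of the methyl would do.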